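Cytotoxicity limits across four closely related compounds

A few compounds are considered here, and "the series" means these few. Any claim that something is new, unique, unknown or untested is made for them only; others in the source may bear on it.

Measured in an ADME assay on Vero cells (Chlorocebus sabaeus) for cytotoxicity, read by MTT assay, with a stated time of 96 h; on this read-out higher numbers stand for lower toxicity in this test and lower numbers for higher toxicity in this test:
compound 1 `C/C(=N\NC(N)=O)c1ccc2c(c1)nc(-c1ccc(Cl)cc1)n2C1CCCCC1`: > 100000 nM
compound 2 `C/C(=N\NC(N)=O)c1ccc2c(c1)nc(-c1ccc(C(F)(F)F)cc1)n2C1CCCCC1`: > 100000 nM
compound 3 `C/C(=N\NC(N)=S)c1ccc2c(c1)nc(-c1ccc(Cl)cc1)n2C1CCCCC1`: > 100000 nM

The value of compound 1 is a limit of this assay, not a number. The value of compound 2 is likewise a limit. The value of compound 3 is also a limit. From compound 1 to compound 2 the change is trifluoromethyl in place of chloro on an aromatic carbon, and the step is a step that the two limits leave unreadable from compound 1 to compound 2. From compound 1 to compound 3 the change is a group of 3 heavy atoms (1 carbon, 1 nitrogen, 1 sulfur; no ring) in place of a group of 3 heavy atoms (1 carbon, 1 nitrogen, 1 oxygen; no ring), on an amine nitrogen, and the step is a step that the two limits leave unreadable from compound 1 to compound 3. Neither step can be sized because of the limit of > 100000 nM in this assay, at which 3 of the 3 values shown sit.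

Compound 4 `C/C(=N\NC(N)=S)c1ccc2c(c1)nc(-c1ccc(C(F)(F)F)cc1)n2C1CCCCC1` has not yet been measured in this assay. It differs from compound 3 by trifluoromethyl in place of chloro on an aromatic carbon, the same change as from compound 1 to compound 2, at a place described in the same words. For compound 4 the step that the limit leaves unreadable from compound 3 to compound 4 is expected to be small, an expectation that rests on (the limit of > 100000 nM in this assay, at which 3 of the 3 values shown sit). Compound 4 is therefore expected to give 150000 nM, within a range from 60000 nM to 400000 nM, and most probably the result will again be only a limit rather than a number.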

Compound 4, half-maximal cytotoxic concentration: > 100000 nM
Compound 4: a limit, no number; the forecaster's own chance of this, stated with the estimate: 85%; the middle value is on the limit's open side.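

In this assay compound 4 gives > 100000 nM, a limit and not a number. Neither the step from compound 3 to compound 4 nor the step from compound 2 to compound 4 can be read, because the values share one limit: the limit of > 100000 nM in this assay, at which 4 of the 4 values shown sit.

The compounds shown leave open whether either change alters the half-maximal cytotoxic concentration at all.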